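The source may hold more compounds than are shown below. What is called first, only, known or untested is meant among the compounds shown, and "the series" means these compounds.

Compound 3 `O=C(Nc1ccc(Oc2ccnc3[nH]ccc23)c(F)c1)c1nn(-c2ccc(Br)cc2)ccc1=O` is the weaker of the two compounds that give a readable number in a functional assay on HepG2 cells (Homo sapiens) for cytotoxicity, read by MTT assay, with a stated time of 72 h; a higher number here means a weaker inhibitor, a lower number a stronger inhibitor: compound 3 gives 68000 nM. Compound 1 `O=C(Nc1ccc(Oc2ccnc3[nH]ccc23)cc1)c1nn(-c2ccccc2)ccc1=O`, which carries a plain phenyl and no fluoro, gives 17800 nM, a lower number by a gap that lies beyond the scatter. For compound 2 `O=C(Nc1ccc(Oc2ccnc3[nH]ccc23)c(F)c1)c1nn(-c2ccc(Cl)cc2)ccc1=O` this assay reports only a limit, > 60000 nM. Going by the values given here, the step that the limit leaves unreadable from compound 2 to compound 3 is therefore not readable, and it is the only measured step that touches the bromophenyl of compound 3; the one comparison with a hard number, compound 1 against compound 3, mixes two changes and cannot be cut apart.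

Compound 4 `O=C(Nc1ccc(Oc2ccnc3[nH]ccc23)c(F)c1)c1nn(-c2ccccc2)ccc1=O` arises from compound 3 by a single change: hydrogen in place of bromo on an aromatic carbon, so that the 4-bromophenyl becomes a phenyl. Compound 4 thus shares the phenyl of compound 1 and the fluoro of compound 3. With compound 1 as the nearer anchor for the phenyl, the estimated step of a 1.9-fold lower number from compound 3 to compound 4 (0.29 log units; within the scatter) is expected to run toward a lower number, though the size rests on little. For compound 4 the expected value in this assay is 35000 nM, with a likely range from 12000 nM to 90000 nM.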

Compound 4, half-maximal inhibitory concentration: 24900 nM
The estimate for compound 4 lay 1.4-fold (0.15 log units) above the measured number; the range from low to high includes it.
By their numbers in this assay, from the lowest: compounds 1 and 4 (each within the scatter of the next); then compound 3.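

The position on the phenyl ring now has a readable step: with the fluoro held in place, hydrogen in place of bromo gives a 2.7-fold lower number from compound 3 to compound 4 (0.44 log units; beyond the scatter) in this assay, so the plain phenyl reads differently from the 4-bromophenyl by more than the scatter. Hydrogen in place of chloro gives an at least 2.4-fold lower number from compound 2 to compound 4 (0.38 log units; beyond the scatter), in the same direction, but this step rests on a limit for compound 2 and not on a number: the limit of > 60000 nM in this assay, at which 1 of the 4 values shown sits. The fluoro, which was mixed with the change on the phenyl in the earlier comparison, can now be read on its own as a 1.4-fold higher number from compound 1 to compound 4 (0.15 log units; within the scatter), so in this small set the gap between the bromo compound and the plain phenyl compounds goes with the bromo and not with the fluoro.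

The step from chloro to bromo still cannot be read, so the two halogens cannot be placed in order against each other. The compounds shown also leave open how a methoxy group, an amine or a carboxylic acid at the same place on the phenyl would read in this assay.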